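A few compounds are considered here, and "the series" means these few. Any claim that something is new, unique, unknown or untested is made for them only; others in the source may bear on it.

Working notes on the chalcone series.

The cytotoxicity read-out is a functional assay on CNE-2 cells (Homo sapiens) for cytotoxicity, read by sulforhodamine B assay, with a stated time of 48 h; a lower number here means a stronger inhibitor, a higher number a weaker inhibitor. Compound 1, `COc1ccc(/C=C/C(=O)c2cccc(-c3cccc(F)c3)c2)cc1`, gives 740 nM in this assay. Compound 2, `Nc1ccc(C(=O)/C=C/c2ccc(O)c(F)c2)cc1-c1ccc(F)cc1`, gives 18100 nM in this assay. Within the data shown here, compound 3, `COc1ccc(/C=C/C(=O)c2cccc(Br)c2)cc1`, is recorded as "not determined" (no result reported) in this assay, so only two numbers are available. Among those two, compound 2 holds the higher value, and the gap that separates compound 2 from compound 1 lies well beyond the scatter, so compound 2 is the weaker inhibitor of the pair. Among the measured compounds shown here, the two compounds differ in several places at once, and no single-point step between measured compounds is available, so nothing can be read from the series about what any one change does.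

Compound 4, `COc1cc(/C=C/C(=O)c2ccc(N)c(-c3ccc(F)cc3)c2)ccc1O`, is the next entry to be measured. It differs from compound 2 in one place: methoxy in place of fluoro on an aromatic carbon. The hydroxy group, the amino group and the fluorophenyl ring of compound 2 are retained. For the measured compounds named here, the change is small in what is counted, and there is no measured step to anchor its size or direction. The expectation is a modest move toward a lower number, within or just beyond the scatter, so the step from compound 2 to compound 4 in this assay is estimated at a 1.8-fold lower number from compound 2 to compound 4 (0.26 log units; within the scatter). For compound 4 the estimate in this assay is 10000 nM, with a range from 3000 nM to 30000 nM.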

Compound 4, half-maximal inhibitory concentration: 5750 nM
Compound 4: the middle estimate sits 1.7-fold (0.24 log units) above what was measured; the range from low to high includes it.
By their numbers in this assay, from the lowest: compound 1; then compound 4; then compound 2.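

In this assay, among these compounds, the change from 3-fluoro-4-hydroxyphenyl to 4-hydroxy-3-methoxyphenyl provides the first single-place step, and it reads a 3.1-fold lower number from compound 2 to compound 4 (0.50 log units; beyond the scatter) with the size printed as beyond the scatter. This shows that the number responds to the group on this aromatic carbon, ortho to a hydroxy group and meta to a large group, with methoxy in place of fluoro as the only difference and the amino group and the fluorophenyl ring unchanged. No measurement at hand speaks to the reason for the step.

The compounds shown leave open whether another group on this carbon, such as a chlorine atom, an ethoxy group or a second hydroxy group, would carry the number further in the same direction or take it back. Also open, from the compounds shown here alone, is whether methoxy in place of fluoro would give a step of similar size and direction if the amino group were replaced by a dimethylamino group or an acetamide.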